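Removing the Tetrazole from a Sterol Acyltransferase Inhibitor

A few compounds are considered here, and "the series" means these few. Any claim that something is new, unique, unknown or untested is made for them only; others in the source may bear on it.

Three compounds share a core with a dodecyl chain on one ring and an amide carrying an aromatic group on its nitrogen. Compound 1 `CCCCCCCCCCCCn1nnc(C(C(=O)Nc2ccc(F)cc2F)c2ccccc2)n1` bears a phenyl on the chain carbon and a 2,4-difluorophenyl on the amide nitrogen; in an assay on liver for inhibition of sterol O-acyltransferase 1 (Rattus norvegicus), using microsomes (a lower number here means a stronger inhibitor, a higher number a weaker inhibitor), compound 1 gives 31 nM. Compound 2 `CCCCCCCCCCCCn1nnc(C(C(=O)Nc2c(C)nn(C)c2C)c2ccccc2)n1` keeps the phenyl and differs only on the amide nitrogen; in this assay compound 2 gives 13 nM. That exchange gives a 2.4-fold lower number from compound 1 to compound 2 (0.38 log units; beyond the scatter). Compound 3 `CCCCCCCCCCCCn1nnc(C(C(=O)Nc2c(C(C)C)cccc2C(C)C)c2nnn[nH]2)n1` is built otherwise, with 1H-tetrazol-5-yl on the saturated chain carbon and 2,6-diisopropylphenyl on the amide nitrogen. In this assay compound 3 reports only a limit, > 5000 nM, which is the limit of > 5000 nM in this assay, at which 1 of the 3 values shown sits; it alone of the three sits at that ceiling and offers no number.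

Compound 4 `CCCCCCCCCCCCn1nnc(CC(=O)Nc2c(C(C)C)cccc2C(C)C)n1` is compound 3 with hydrogen in place of 1H-tetrazol-5-yl on a saturated chain carbon bound to an aromatic carbon and a carbonyl carbon. Among the compounds with values here, no measured step touches this carbon: the only measured step changed the amide nitrogen, and compounds 1 and 2 carry a phenyl there rather than hydrogen, so they do not describe this change. Because compound 3 stands at the limit > 5000 nM, the size of the step cannot be read from what is measured. For compound 4 the expected value in this assay is 300 nM, within 40 nM to 3000 nM. This estimate means an expected at least 16-fold lower number from compound 3 to compound 4 (1.22 log units; beyond the scatter).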

Compound 4, half-maximal inhibitory concentration: 5 nM
Beside the measured number, compound 4's estimate is 60-fold (1.78 log units) above it, and the stated range ends above it.
By their numbers in this assay, from the lowest: compound 4; then compound 2; then compound 1. At a limit, above all of these: compound 3.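

Within the data shown here, replacing 1H-tetrazol-5-yl with hydrogen on the saturated chain carbon bound to an aromatic carbon and a carbonyl carbon gives an at least 1000-fold lower number from compound 3 to compound 4 (3.00 log units; beyond the scatter), and this is the first measured step to touch that carbon. Among these compounds, compound 3 gives only a limit in this assay, > 5000 nM, so this step sets a minimum for the change and not its full size: the limit of > 5000 nM in this assay, at which 1 of the 4 values shown sits. Even as a minimum, the change at this carbon, made with the 2,6-diisopropylphenyl held on the amide nitrogen, is large, whereas the one earlier step, at the amide nitrogen, is modest at a 2.4-fold lower number from compound 1 to compound 2 (0.38 log units; beyond the scatter).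

The compounds shown leave open how a carboxylic acid, an amine or a methyl group on this carbon would read in this assay with the 2,6-diisopropylphenyl kept on the amide nitrogen, and so whether the tetrazole alone or any larger group there goes with the weak result. They also leave open what a phenyl on this carbon does in that setting, for compound 1 and compound 2 each differ from compound 4 in two places.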